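Aryl Swaps on the Ring Nitrogen: Inhibition Holds Steady

A few compounds are considered here, and "the series" means these few. Any claim that something is new, unique, unknown or untested is made for them only; others in the source may bear on it.

Compound 1 `Cc1cccc(N2C(=O)CSC2c2cccc(C(=O)NCCCCc3ccccc3)c2)c1`: 84%
Compound 2 `COc1cc(F)ccc1N1C(=O)CSC1c1cccc(C(=O)NCCCCc2ccccc2)c1`: 81%
Compound 3 `COc1cccc(OC)c1N1C(=O)CSC1c1cccc(C(=O)NCCCCc2ccccc2)c1`: 80%

In a functional assay on HOS cells (Homo sapiens) for inhibition, read by CCK-8 assay, with a stated time of 72 h, tested at 1 uM (a higher number here means more inhibition at the concentration tested (going by the name of the read-out), a lower number less inhibition), compound 1 gives 84%, compound 2 gives 81% and compound 3 gives 80%. Compound 3 carries the lowest of the three numbers, yet every step toward it lies within the scatter: a number 4 percentage points lower from compound 1 to compound 3 (within the scatter), a number 1 percentage points lower from compound 2 to compound 3 (within the scatter), and likewise a number 3 percentage points lower from compound 1 to compound 2 (within the scatter). Compound 4 `CC(F)(F)c1cccc(N2C(=O)CSC2c2cccc(C(=O)NCCCCc3ccccc3)c2)c1` differs from compound 3 by a group of 10 heavy atoms (8 carbon, 2 fluorine; one six-membered aromatic ring of carbon only) in place of a group of 10 heavy atoms (8 carbon, 2 oxygen; one six-membered aromatic ring of carbon only), on an amide-type nitrogen in a ring. Among the measured compounds shown here, no measured step involves the entering group; the three that exist show only that exchanging one aryl ring for another on this nitrogen has not moved the read-out beyond the scatter. Compound 4 is therefore expected to show a step of no change at the digits printed from compound 3 to compound 4 (within the scatter). Compound 4 is estimated at 80%, within 66% to 90%.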

Compound 4, a percentage reported as inhibition, at one concentration (the size of the read-out at that concentration, not a potency): 23%
Beside the measured number, compound 4's estimate is 57 percentage points above it; measured number outside the range, below it.
By their numbers in this assay, from the lowest: compound 4; then compounds 3, 2 and 1 (each within the scatter of the next).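

In this assay, exchanging the aryl ring on the amide-type nitrogen does not always leave the read-out in place: compound 4 breaks from the others, with a number 57 percentage points lower from compound 3 to compound 4 (beyond the scatter) and a number 58 percentage points lower from compound 2 to compound 4 (beyond the scatter). The cleanest comparison is 1,1-difluoroethyl in place of methyl on an aromatic carbon, which gives a number 61 percentage points lower from compound 1 to compound 4 (beyond the scatter), so a change in one substituent on that ring is enough to produce a large step. No available evidence bears on the reason for this drop. Going by these compounds, what an ethyl or a trifluoromethyl group would give on that aromatic carbon remains open, and with it whether the drop goes with the fluorine atoms or with the added carbon.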